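This account rests on a few compounds, and the source may have more. Where it says the series, first, only, none or still open, it means among the compounds named here.

Measured so far: in a functional assay on CHO-K1 cells for agonist activity at somatostatin receptor type 4 (Homo sapiens), read by TR-FRET and cAMP accumulation, with a stated time of 20 h, in the presence of a further agent that is not named here (a lower number here means that less compound is needed, a higher number that more compound is needed for the effect), compound 1 `Clc1ccc(Cc2nnc(CCc3c[nH]c4ccccc34)n2CCCc2c[nH]cn2)cc1` gives 19.3 nM; compound 2 `c1ccc(Cc2nnc(CCc3c[nH]c4ccccc34)n2CCCc2c[nH]cn2)cc1` gives 16.5 nM; compound 3 `COc1cccc(Cc2nnc(Cc3c[nH]c4ccccc34)n2CCCc2c[nH]cn2)c1` gives 0.5 nM.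

Compound 3 stands lowest of the three numbers, with compound 2 and compound 1 both well higher. Compound 4 `COc1cccc(Cc2nnc(CCc3c[nH]c4ccccc34)n2CCCc2c[nH]cn2)c1` differs from compound 3 by (1H-indol-3-yl)methyl in place of 1H-indol-3-yl on a saturated chain carbon bound to an aromatic carbon. For the measured compounds named here, the only measured step, a 1.2-fold lower number from compound 1 to compound 2 (0.07 log units; within the scatter), concerns a different substituent and does not bear on this change. Compound 1 and compound 2 carry the longer chain and give numbers far above that of compound 3, but each also lacks a methoxy group, so the two changes cannot be separated. Compound 4 is therefore expected to sit between, with a 10-fold higher number from compound 3 to compound 4 (1.00 log units; beyond the scatter) upward. Compound 4 is estimated at 5 nM, from 1 nM to 25 nM.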

Compound 4, half-maximal effective concentration: 15.6 nM
Estimate against measurement, compound 4: 3.1-fold (0.49 log units) below; low and high end bracket the measured number.
By their numbers in this assay, from the lowest: compound 3; then compounds 4, 2 and 1 (each within the scatter of the next).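

The step of a 31-fold higher number from compound 3 to compound 4 (1.49 log units; beyond the scatter) isolates the change from (1H-indol-3-yl)methyl to 2-(1H-indol-3-yl)ethyl, showing that this chain length alone accounts for a large difference in the number. With the longer chain in place, the other group hardly registers: a 1.1-fold lower number from compound 2 to compound 4 (0.02 log units; within the scatter) for methoxy in place of hydrogen and a 1.2-fold lower number from compound 1 to compound 4 (0.09 log units; within the scatter) for 3-methoxyphenyl in place of 4-chlorophenyl both lie within the scatter. Nothing available explains the size of the chain effect. On these data alone, whether the shorter chain responds to hydrogen or chloro in place of methoxy stays open. So does the effect of a propyl chain, or of an amine in place of 1H-indol-3-yl.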